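This account rests on a few compounds, and the source may have more. Where it says the series, first, only, none or still open, it means among the compounds named here.

Working notes on the series. Compound 3 `Cc1ccc(-c2c(C)[nH]c(=O)n2C)cc1` gives 85300 nM in a functional assay on brain (Rattus norvegicus, strain Wistar) for inhibition; a higher number here means a weaker inhibitor, a lower number a stronger inhibitor. Among the measured compounds shown here, of the two numbers so far it stands highest; its nearest neighbour is compound 1 `CCCCc1ccc(-c2c(CC)[nH]c(=O)n2C)cc1`, and compound 1 gives 13900 nM in this assay, a lower number by a margin beyond the scatter. Compound 2 `CCCCn1c(-c2ccccc2)c(C)[nH]c1=O` reaches only a limit of this assay, > 100000 nM, and is not a number; one of three values sits at the limit of > 100000 nM in this assay, at which 1 of the 3 values shown sits. Compound 4 `CCCCCCCc1ccc(-c2c(C)[nH]c(=O)n2C)cc1` is the next step from compound 3, with hexyl in place of hydrogen on a saturated chain carbon bound to an aromatic carbon. For the measured compounds named here, no step between measured compounds is available to size the change. Since compound 1 carries a longer chain than compound 3 and compound 1 gives 13900 nM, compound 4 is expected to come in lower, estimated at 4000 nM with a range of 800 nM to 20000 nM, a step of a 21-fold lower number from compound 3 to compound 4 (1.33 log units; beyond the scatter).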

Compound 4, half-maximal inhibitory concentration: 8400 nM
Compound 4: the middle estimate sits 2.1-fold (0.32 log units) below what was measured, and the stated range covers the measured number.
By their numbers in this assay, from the lowest: compounds 4 and 1 (each within the scatter of the next); then compound 3. At a limit, above all of these: compound 2.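

In this assay, among the compounds shown here, the change from methyl to heptyl on the shared core gives a 10-fold lower number from compound 3 to compound 4 (1.01 log units; beyond the scatter) and is the first sized step, a large one. This place on the core therefore accepts a much longer chain, and here the added hexyl goes with a stronger inhibitor. Nothing measured on hand accounts for the size of this step.

On these data alone, whether the number keeps falling with chain length stays open, since one step fixes no trend. A shorter chain such as propyl, a longer chain such as decyl, or an amine at the chain end would each test this place further.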